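The compounds below may be only part of what the source reports. "The series", "measured", "known", "first", "only" and "open" are said of these compounds alone.

Measured compounds in an assay on isolated protein for inhibition of protein deacetylase HDAC6 (Homo sapiens), with a stated time of 15 min, tested at 1 uM; a higher number here means more inhibition at the concentration tested (going by the name of the read-out), a lower number less inhibition:

compound 1 `CNC(=O)CCCCCCCn1nc(-c2cnc3[nH]ccc3c2)c2c(N)ncnc21`: 100%
compound 2 `Nc1ncnc2c1c(-c1cnc3[nH]ccc3c1)nn2CCCCCCC(=O)NO`: 99.1%
compound 3 `CNC(=O)CCCCCCCn1nc(-c2ccc3oc(N)nc3c2)c2c(N)ncnc21`: 99.1%

All three sit together at the top of the range, and compound 3 stands level with compound 2 at the digits given. The change from compound 1 to compound 2 is hydroxycarbamoyl in place of (methylcarbamoyl)methyl on a saturated chain carbon, six bonds along the chain from an aromatic nitrogen, and it made a number 0.9 percentage points lower from compound 1 to compound 2 (within the scatter). Compound 4 `Nc1nc2cc(-c3nn(CCCCCCC(=O)NO)c4ncnc(N)c34)ccc2o1` carries the same change on the core of compound 3: hydroxycarbamoyl in place of (methylcarbamoyl)methyl on a saturated chain carbon, six bonds along the chain from an aromatic nitrogen, with the place described in the same words in both cases. The two cores differ by a group of 10 heavy atoms (7 carbon, 2 nitrogen, 1 oxygen; one five-membered aromatic ring with 2 hetero atoms, one six-membered aromatic ring of carbon only) in place of a group of 9 heavy atoms (7 carbon, 2 nitrogen; one five-membered aromatic ring with 1 hetero atom, one six-membered aromatic ring with 1 hetero atom), on an aromatic carbon, which made a number 0.9 percentage points lower from compound 1 to compound 3 (within the scatter).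

From compound 3 to compound 4 the expected step is a number 1.1 percentage points lower from compound 3 to compound 4 (within the scatter), resting on a number 0.9 percentage points lower from compound 1 to compound 2 (within the scatter) and on compound 3 already giving 99.1% in this assay. Compound 4 is therefore estimated at 98%, between 93% and 100%.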

Compound 4, a percentage reported as inhibition, at one concentration (the size of the read-out at that concentration, not a potency): 99%
Compound 4: the middle estimate sits 1 percentage points below what was measured, and the stated range covers the measured number.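

On the core of compound 3, hydroxycarbamoyl in place of (methylcarbamoyl)methyl gave a number 0.1 percentage points lower from compound 3 to compound 4 (within the scatter) in this assay, and the change carries across the two cores without a detectable difference: the same change on two cores in this assay, a number 0.9 percentage points lower (within the scatter) from compound 1 to compound 2 and a number 0.1 percentage points lower (within the scatter) from compound 3 to compound 4, 0.8 percentage points apart, within the scatter of two such steps
The change of core, read with the hydroxycarbamoyl chain, gave a number 0.1 percentage points lower from compound 2 to compound 4 (within the scatter), and it too carries over: the same change on two cores in this assay, a number 0.9 percentage points lower (within the scatter) from compound 1 to compound 3 and a number 0.1 percentage points lower (within the scatter) from compound 2 to compound 4, 0.8 percentage points apart, within the scatter of two such steps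
This shows agreement at one concentration only; with all four compounds at the top of the range, the read-out gives no potency and cannot show whether the steps would stay alike where inhibition is partial.

Open, on these data alone, is how a carboxylic acid or a primary amide at the chain end would read in this assay. As far as these compounds go, a shorter or longer chain on either core is also open.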